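Tetrazolylacetamide series: 3,4-difluorophenyl to 3-(trifluoromethyl)phenyl

The compounds below may be only part of what the source reports. "The series", "measured", "known", "first", "only" and "open" are said of these compounds alone.

Within the data shown here, compound 3 `Cc1cc(NC(=O)Cn2nnc(-c3ccc(F)c(F)c3)n2)n(C2CCCCC2)n1` gives 93% in an assay on HEK293 cells for activation of Kir3.1/Kir3.2 (Homo sapiens), read by thallium flux (on this read-out higher numbers stand for larger maximal responses and lower numbers for smaller maximal responses), the only plain number among the three entries. For compound 1 `CCC(C)n1nc(C)cc1NC(=O)Cn1nnc(-c2ccccc2)n1` this assay reports a limit rather than a number, > 69%, which is the limit of > 69% in this assay, at which 1 of the 3 values shown sits. Compound 2 `Cc1nc(-c2ccccc2)c(NC(=O)Cn2nnc(-c3ccccc3)n2)s1` is recorded in this assay as "not active" (no number reported). Among the measured compounds shown here, no step between two measured compounds that differ in one place is available, so the move to compound 4 `Cc1cc(NC(=O)Cn2nnc(-c3cccc(C(F)(F)F)c3)n2)n(C2CCCCC2)n1` rests on the change alone: 3-(trifluoromethyl)phenyl in place of 3,4-difluorophenyl on an aromatic carbon. A step of a number 8 percentage points lower from compound 3 to compound 4 (within the scatter) is expected, small enough to stay within the usual scatter rather than a clear shift in either direction. In this assay compound 4 is estimated at 85%, with a range from 65% to 105%.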

Compound 4, largest response reached (Emax), in percent of the reference or control that the assay uses: 86%
Beside the measured number, compound 4's estimate is 1 percentage points below it; the measured number falls inside the stated range.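

In this assay, among these compounds, the change gives a number 7 percentage points lower from compound 3 to compound 4 (within the scatter), the first comparison between compounds that differ in one place. At this aromatic carbon of the five-membered aromatic ring with 4 nitrogen, the two fluorinated phenyl groups therefore cannot be told apart on maximal response. No available data bear on a reason for this result.

Still open, on these data alone, is how the response changes with a phenyl ring carrying an amine or a carboxylic acid at this position. As far as these compounds go, a pyridine in place of the phenyl ring is equally open.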